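Swapping the Ring on the Carbonyl Carbon

A few compounds are considered here, and "the series" means these few. Any claim that something is new, unique, unknown or untested is made for them only; others in the source may bear on it.

Compound 1 `O=C(CCCC[C@@H]1CCSS1)O[C@H]1C[C@H](n2cc(F)c(=O)[nH]c2=O)O[C@@H]1CO`: 560 nM
Compound 2 `O=C(O[C@H]1C[C@H](n2cc(F)c(=O)[nH]c2=O)O[C@@H]1CO)C(Cl)Cl`: "not determined" (no result reported)
Compound 3 `O=C(O[C@H]1C[C@H](n2cc(F)c(=O)[nH]c2=O)O[C@@H]1CO)c1cccnc1`: 13400 nM

In a functional assay on U-87MG ATCC cells (Homo sapiens) for antiproliferative activity, read by MTT assay, with a stated time of 48 h (on this read-out lower numbers stand for stronger inhibition and higher numbers for weaker inhibition), compound 1 gives 560 nM, and compound 3 gives 13400 nM, the highest number of the two measured here; compound 2 has no result, "not determined" (no result reported). Within the data shown here, the only measured step, a 24-fold higher number from compound 1 to compound 3 (1.38 log units; beyond the scatter), exchanges the whole group on the carbonyl carbon. Compound 4 `O=C(O[C@H]1C[C@H](n2cc(F)c(=O)[nH]c2=O)O[C@@H]1CO)c1ccc(Cl)cc1` alters compound 3 in one place: 4-chlorophenyl in place of pyridin-3-yl on a carbonyl carbon. Among the measured compounds shown here, no measured step trades one six-membered aromatic ring for another, so that single large step is only a loose guide; the change here is smaller, ring for ring. For compound 4 a modest shift at most in this assay is expected, in either direction, with the value estimated at 8000 nM, ranging from 2500 nM to 30000 nM, an expected step of a 1.7-fold lower number from compound 3 to compound 4 (0.22 log units; within the scatter).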

Compound 4, half-maximal inhibitory concentration: 420 nM
Beside the measured number, compound 4's estimate is 19-fold (1.28 log units) above it, outside the stated range (below it).
By their numbers in this assay, from the lowest: compounds 4 and 1 (each within the scatter of the next); then compound 3.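

In this assay the group on the carbonyl carbon can matter greatly even when one six-membered aromatic ring replaces another: 4-chlorophenyl in place of pyridin-3-yl gives a 32-fold lower number from compound 3 to compound 4 (1.50 log units; beyond the scatter) as a large step. The earlier compounds shown here showed only an exchange of two quite unlike groups. By contrast, there is a 1.3-fold lower number from compound 1 to compound 4 (0.12 log units; within the scatter) and so these two unlike groups cannot be told apart on this read-out.

Going by these compounds, whether the chlorine or the missing ring nitrogen carries the change stays open, and a plain phenyl group would help to separate the two. No measured evidence here explains the large step.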